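The compounds below may be only part of what the source reports. "The series", "measured", "known", "first", "only" and "open" are said of these compounds alone.

Measured so far in a functional assay on CCRF-CEM cells (Homo sapiens) for inhibition; on this read-out lower numbers stand for stronger inhibition and higher numbers for weaker inhibition:
compound 1 `CC(=O)OC[C@H]1O[C@@H](n2cnc3c(-c4ccc(Cl)cc4)ncnc32)[C@H](OC(C)=O)[C@@H]1OC(C)=O`: 4300 nM
compound 2 `CC(=O)OC[C@H]1O[C@@H](n2cnc3c(-c4ccccc4)ncnc32)[C@H](OC(C)=O)[C@@H]1OC(C)=O`: 10500 nM

Within the data shown here, compound 2 gives the highest number of the two in this assay; its only neighbour is compound 1, and the step between them, a 2.4-fold higher number from compound 1 to compound 2 (0.39 log units; beyond the scatter), was modest but beyond the scatter.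

Compound 3 `CCOc1ccc(-c2ncnc3c2ncn3[C@@H]2O[C@H](COC(C)=O)[C@@H](OC(C)=O)[C@H]2OC(C)=O)cc1` differs from compound 2 by ethoxy in place of hydrogen on an aromatic carbon. Among the measured compounds shown here, only one measured step bears on this, and only loosely: a 2.4-fold higher number from compound 1 to compound 2 (0.39 log units; beyond the scatter) concerns the same place on the ring but a different group, chloro. Its direction, a higher number once that carbon carries only hydrogen, suggests that a group at that place is tolerated or helps. Nothing measured covers ethoxy itself. The step from compound 2 to compound 3 is therefore expected to be a modest move toward a lower number, a 1.8-fold lower number from compound 2 to compound 3 (0.24 log units; within the scatter), not far beyond the scatter. Compound 3 is expected at about 6000 nM, within 2500 nM to 15000 nM.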

Compound 3, half-maximal inhibitory concentration: 3800 nM
Beside the measured number, compound 3's estimate is 1.6-fold (0.20 log units) above it, and the stated range covers the measured number.
By their numbers in this assay, from the lowest: compounds 3 and 1 (each within the scatter of the next); then compound 2.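

In this assay the aromatic carbon that holds chloro in compound 1 also takes ethoxy, with a 2.8-fold lower number from compound 2 to compound 3 (0.44 log units; beyond the scatter) on replacing hydrogen, so two different groups at that carbon now go with a lower number than hydrogen does. The two groups give no order between them: the exchange gives a 1.1-fold lower number from compound 1 to compound 3 (0.05 log units; within the scatter) and chloro and ethoxy cannot be told apart on this read-out. Nothing at hand speaks to what lies behind either step.

As far as these compounds go, whether a longer chain such as butoxy, an amine or a carboxylic acid at the same carbon would keep this lower number stays open. Also open, from the compounds shown here alone, is whether the gain over hydrogen would hold with a change elsewhere on the shared core.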